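This account rests on a few compounds, and the source may have more. Where it says the series, first, only, none or still open, it means among the compounds named here.

Working notes on the series in a functional assay on SF-268 cells (Homo sapiens) for inhibition, read by colorimetric assay and sulforhodamine B assay, with a stated time of 48 h; a higher number here means a weaker inhibitor of growth, a lower number a stronger inhibitor of growth: compound 1 `CCCCCCCCCCCC[C@@H](O)[C@H]1CC[C@H]([C@H](O)CCCCCCCCCCNC(=O)c2cccs2)O1` gives 3980 nM, compound 2 `CCCCCCCCCCCC[C@@H](O)[C@H]1CC[C@H]([C@H](O)CCCCCCCCCCNC(=O)c2ccco2)O1` gives 100000 nM, and compound 3 `CCCCCCCCCCCC[C@@H](O)[C@H]1CC[C@H]([C@H](O)CCCCCCCCCCNC(=O)c2ccoc2)O1` gives 100000 nM. Compound 3 is level with compound 2, and together they hold the highest of the three numbers. Compound 4 `CCCCCCCCCCCC[C@@H](O)[C@H]1CC[C@H]([C@H](O)CCCCCCCCCCNC(=O)c2ccsc2)O1` is the next to be read, with this difference: thiophen-3-yl in place of furan-3-yl on a carbonyl carbon. Two large steps, beyond the scatter, bear on it: a 25-fold higher number from compound 1 to compound 2 (1.40 log units; beyond the scatter) and a 25-fold higher number from compound 1 to compound 3 (1.40 log units; beyond the scatter). The exchange between furans, no change at the digits printed from compound 2 to compound 3 (within the scatter), lies within the scatter. Reading a 25-fold higher number from compound 1 to compound 3 (1.40 log units; beyond the scatter) in reverse, a large step to a lower number is expected in this assay, although no thiophen-3-yl amide has yet been measured. The expected change is a 20-fold lower number from compound 3 to compound 4 (1.30 log units; beyond the scatter). The estimate for compound 4 is 5000 nM, within a range of 1500 nM to 30000 nM.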

Compound 4, concentration for 50% growth inhibition: 100000 nM
Compound 4: the middle estimate sits 20-fold (1.30 log units) below what was measured; measured number outside the range, above it.
By their numbers in this assay, from the lowest: compound 1; then compounds 2, 3 and 4 (each within the scatter of the next).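

In this assay, a thiophene ring on the carbonyl carbon is not enough on its own: thiophen-3-yl in place of furan-3-yl gives no change at the digits printed from compound 3 to compound 4 (within the scatter), and thiophen-3-yl in place of furan-2-yl gives no change at the digits printed from compound 2 to compound 4 (within the scatter). The thiophene isomer decides the reading instead, with thiophen-3-yl in place of thiophen-2-yl giving a 25-fold higher number from compound 1 to compound 4 (1.40 log units; beyond the scatter). No measured evidence accounts for this gap between the two thiophene amides. Still open, from the compounds shown here alone, is how other groups on this carbonyl carbon, such as phenyl or pyridin-2-yl, would read against the thiophen-2-yl amide of compound 1.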